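A few compounds are considered here, and "the series" means these few. Any claim that something is new, unique, unknown or untested is made for them only; others in the source may bear on it.

In a functional assay on HeLa cells (Homo sapiens) for cytotoxicity, read by XTT assay, with a stated time of 24 h (a lower number here means a stronger inhibitor, a higher number a weaker inhibitor), three compounds have been measured so far:
compound 1 `Cc1cc(Cl)c2c(c1O)C(=O)C=CC2=O` with 10100 nM
compound 2 `Cc1cc(O)c2c(c1Cl)C(=O)C=CC2=O` with 13500 nM
compound 3 `CCOc1c(C)cc(Cl)c2c1C(=O)C=CC2=O` with 33200 nM

Compound 1 and compound 2 are built from the same atoms joined differently; the difference between the two cores is not broken down here, and their two values lie within the usual scatter of each other. Compound 3 comes from compound 1 by ethyl in place of hydrogen on an oxygen on an aromatic ring, and in this assay this gives a 3.3-fold higher number from compound 1 to compound 3 (0.52 log units; beyond the scatter), a move towards a weaker inhibitor. Compound 4 `CCOc1cc(C)c(Cl)c2c1C(=O)C=CC2=O`, not yet measured, comes from compound 2 by the same change, (ethyl in place of hydrogen on an oxygen on an aromatic ring), at a place described in the same words. Because the same change gave a 3.3-fold higher number from compound 1 to compound 3 (0.52 log units; beyond the scatter), compound 4 is expected to show a step of similar size, a 3.1-fold higher number from compound 2 to compound 4 (0.49 log units; beyond the scatter). Among the measured compounds shown here, with only one earlier example, the expectation is rough. Compound 4 is therefore estimated at 42000 nM, likely between 18000 nM and 95000 nM.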

Compound 4, half-maximal inhibitory concentration: 19000 nM
The estimate for compound 4 lay 2.2-fold (0.34 log units) above the measured number, within the range that was stated.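

In this assay, the change from hydroxy to ethoxy on the core of compound 2 gives a 1.4-fold higher number from compound 2 to compound 4 (0.15 log units; within the scatter). Set beside the same change on the core of compound 1, the two steps cannot be told apart: the same change on two cores in this assay, a 3.3-fold higher number (0.52 log units; beyond the scatter) from compound 1 to compound 3 and a 1.4-fold higher number (0.15 log units; within the scatter) from compound 2 to compound 4, 2.3-fold (0.37 log units) apart, within the scatter of two such steps. Among the compounds shown here, this fits a change that carries over between the two cores, but two pairs are too few to prove it, and they do not show that the change has the same size on both cores, since only the step on the core of compound 1 lies beyond the scatter.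

The compounds shown leave open how other groups on that oxygen would behave, such as methyl, a longer chain like butyl, or a chain ending in an amine. They also leave open whether the two cores would still match with those groups.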